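Aryl Exchange at the Five-Membered Ring: Expectation for Compound 3

The compounds below may be only part of what the source reports. "The series", "measured", "known", "first", "only" and "open" are said of these compounds alone.

Compound 1, `Cc1cc(NC(=O)Cn2nnc(-c3ccccc3)n2)n(C2CC2)n1`: > 5000 nM
Compound 2, `Cc1cc(NC(=O)Cn2nnc(-c3ccc(Cl)c(Cl)c3)n2)n(C2CCCCC2)n1`: 1220 nM

Going by the values given here, in an assay on HEK293 cells for activation of Kir3.1/Kir3.2 (Homo sapiens), read by thallium flux (on this read-out higher numbers stand for an effect only at larger amounts of compound and lower numbers for an effect already at smaller amounts), compound 2 gives 1220 nM, the only number available here. Compound 1 gives > 5000 nM in this assay, which is a limit rather than a number (the limit of > 5000 nM in this assay, at which 1 of the 2 values shown sits). Among the compounds with values here, compound 3, `Cc1ccc(-c2nnn(CC(=O)Nc3cc(C)nn3C3CCCCC3)n2)cc1`, differs from compound 2 by 4-methylphenyl in place of 3,4-dichlorophenyl on an aromatic carbon; no measured pair isolates such a change, so its size is not known from the data. The change is expected to give a step no larger than the scatter, or a modest move toward weaker activity, a 2.0-fold higher number from compound 2 to compound 3 (0.31 log units; beyond the scatter). Compound 3 is therefore estimated at 2500 nM, between 900 nM and 7000 nM.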

Compound 3, half-maximal effective concentration: 111 nM
The estimate for compound 3 lay 23-fold (1.35 log units) above the measured number; measured number below the stated range.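

Replacing 3,4-dichlorophenyl with 4-methylphenyl gives an 11-fold lower number from compound 2 to compound 3 (1.04 log units; beyond the scatter) in this assay. This is the first change shown in a single place, and it shows that the aryl group on this aromatic carbon strongly affects the read-out and that the chlorine atoms are not needed for activity here. Nothing shown accounts for the size of this step. From the compounds shown here alone, it remains open whether the step comes from the added methyl or the lost chlorine atoms, and how 4-chlorophenyl or 4-methoxyphenyl would read at this position.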